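Replacing Methyl with Oxolan-2-yl on the Side Chain

The source may report more compounds than this note shows. Statements on the series, on what has been measured and on what is new or still open speak of the compounds shown alone.

In a physicochemical assay for lipophilicity, at pH 7.4 (on this read-out higher numbers stand for higher lipophilicity and lower numbers for lower lipophilicity), compound 2 `Cc1cc(C)c(CN2CCc3c(Cl)cc([C@H](C)CO)c(Cl)c3C2=O)c(=O)[nH]1` gives 2.6, the higher of the two compounds with a single reading. Compound 1 `Cc1cc(C)c(CN2CCc3c(Cl)cc([C@H](CO)[C@H]4CCOC4)c(Cl)c3C2=O)c(=O)[nH]1`, the other of these, gives 2. Compound 3 `CCOC(c1cc(Cl)c2c(c1Cl)C(=O)N(Cc1c(C)cc(C)[nH]c1=O)CC2)C1CS(=O)(=O)C1` has two readings, 2.4; 2.3 (2 entries), but no single-place comparison links it to the others, so it offers little guidance here.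

The next structure is compound 4 `Cc1cc(C)c(CN2CCc3c(Cl)cc([C@@H](CO)[C@H]4CCCO4)c(Cl)c3C2=O)c(=O)[nH]1`. Its change is oxolan-2-yl in place of methyl on a saturated chain carbon bound to an aromatic carbon and a saturated chain carbon.

Compound 1 is the closest guide, since its side chain also carries a five-membered non-aromatic ring. Within the data shown here, the one measured step is a number 0.60 log units higher from compound 1 to compound 2 (beyond the scatter), a modest change beyond the scatter. Adding the ring here runs in the opposite direction, although the group is not identical to that in compound 1. A fall of similar size is therefore expected, and the estimated step is a number 0.50 log units lower from compound 2 to compound 4 (beyond the scatter). For compound 4, the expected value in this assay is 2.1, with an estimated range of 1.7 to 2.5.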

Compound 4, distribution coefficient: 2.5
Estimate against measurement, compound 4: 0.40 log units below; measured number inside the range.
By their numbers in this assay, from the lowest: compound 1; then compounds 4 and 2 (each within the scatter of the next).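

In this assay, oxolan-2-yl in place of methyl on this saturated chain carbon does not move the reading beyond the usual scatter: a number 0.10 log units lower from compound 2 to compound 4 (within the scatter). Adding a five-membered non-aromatic ring to the side chain therefore does not by itself bring a fall, and compound 4 goes against the reading suggested by compound 1 alone, since two groups with the same atom counts and the same kind of ring still differ beyond the scatter: a number 0.50 log units higher from compound 1 to compound 4 (beyond the scatter). No measurement shown here explains why these two ring-bearing groups part.

Compounds 1 and 4 differ in how the group is built as a whole, so the shown data cannot separate the place where the ring is joined from the arrangement at the stereocentres. From the compounds shown here alone, how a longer chain or an amine would read on this saturated chain carbon also remains open.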